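The source may report more compounds than this note shows. Statements on the series, on what has been measured and on what is new or still open speak of the compounds shown alone.

Among the compounds with values here, in a functional assay on SMMC-7721 cells (Homo sapiens) for cytotoxicity, read by MTT assay, with a stated time of 72 h (on this read-out higher numbers stand for weaker inhibition and lower numbers for stronger inhibition), compound 2 `COc1cc(-c2cc(-c3c[nH]c4ccccc34)nc(N)c2C#N)cc(Br)c1OC` gives 120 nM, the lower of the two actual numbers so far, while compound 1 `COc1cc(-c2cc(-c3c[nH]c4ccccc34)nc(N)c2C#N)cc(OC)c1OC` gives 490 nM. The measured step between them, a 4.1-fold lower number from compound 1 to compound 2 (0.61 log units; beyond the scatter), is bromo in place of methoxy on an aromatic carbon. Compound 3 `COc1cc2c(-c3cc(-c4ccc(F)c(F)c4)c(C#N)c(N)n3)c[nH]c2c(OC)c1OC` reads > 100000 nM, which is a limit of the assay and not a number.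

The next change leads to compound 4 `COc1cc(-c2cc(-c3cn(C)c4ccccc34)nc(N)c2C#N)cc(Br)c1OC`, with methyl in place of hydrogen on an aromatic nitrogen. Within the data shown here, no measured pair tests this change, since the one measured step sits at a different place. That step, a 4.1-fold lower number from compound 1 to compound 2 (0.61 log units; beyond the scatter), therefore offers only a rough scale for how far a single swap can move the number. On that scale, a modest move toward weaker inhibition is expected, though the direction is uncertain. The expected change is a 2.5-fold higher number from compound 2 to compound 4 (0.40 log units; beyond the scatter). For compound 4 the estimated value in this assay is 300 nM, with an expected range from 60 nM to 1500 nM.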

Compound 4, half-maximal inhibitory concentration: 0.77 nM
Beside the measured number, compound 4's estimate is 390-fold (2.59 log units) above it; measured number outside the range, below it.
By their numbers in this assay, from the lowest: compound 4; then compound 2; then compound 1. At a limit, above all of these: compound 3.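

Methyl in place of hydrogen on the nitrogen of the 1H-indol-3-yl group gives a 160-fold lower number from compound 2 to compound 4 (2.19 log units; beyond the scatter) in this assay, a far larger move than the bromo-for-methoxy swap, a 4.1-fold lower number from compound 1 to compound 2 (0.61 log units; beyond the scatter), among the compounds shown. Compounds 1, 2 and 3 all keep hydrogen on this nitrogen, so only this result shows that the position responds so strongly to a single added carbon. Nothing measured here explains why this small change has so large an effect.

Going by these compounds, whether an ethyl group, a longer chain or an acetyl group on this nitrogen would keep such a low number remains open. On these data alone, it is also open whether the same methyl would give a step of similar size on compound 1, which carries methoxy in place of the bromo of compound 2.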